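The source may report more compounds than this note shows. Statements on the series, on what has been measured and on what is new or still open speak of the compounds shown alone.

Measured so far in a functional assay for inhibition, with a stated time of 30 min, tested at 1 mM; a higher number here means more inhibition at the concentration tested (going by the name of the read-out), a lower number less inhibition:
- compound 1, `COc1cc(/C(Cl)=C/C=C(\C#N)C(=O)c2c(C)[nH]c3ccccc23)cc(OC)c1OC`: compound 1 gives 14.5%
- compound 2, `COc1cc(/C(Cl)=C/C=C(\C#N)C(=O)c2c[nH]c3ccc(Br)cc23)cc(OC)c1OC`: compound 2 gives 26.3%

For the measured compounds named here, compound 2 holds the highest of the two numbers in this assay; its nearest neighbour is compound 1, and the only measured step, a number 11.8 percentage points higher from compound 1 to compound 2 (beyond the scatter), separates them, a modest rise that lies beyond the scatter and goes with 5-bromo-1H-indol-3-yl in place of 2-methyl-1H-indol-3-yl on the carbonyl carbon.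

Compound 3, `COc1ccc2[nH]cc(C(=O)/C(C#N)=C/C=C(\Cl)c3cc(OC)c(OC)c(OC)c3)c2c1`, is not yet measured. It differs from compound 2 in one place: methoxy in place of bromo on an aromatic carbon

Going by the values given here, no measured step concerns this exchange. Among the compounds with values here, the one step known, from compound 1 to compound 2, changes the ring system attached to the carbonyl carbon, not a single substituent on the six-membered aromatic ring, so it gives no direct bearing on methoxy replacing bromo. Within the data shown here, with nothing to lean on, the expected step of a number 4.3 percentage points lower from compound 2 to compound 3 (within the scatter) is taken as none beyond the scatter, though the modest size of the one known step allows a shift of similar size either way. Compound 3 is therefore estimated at 22% in this assay, within a range from 8% to 38%.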

Compound 3, a percentage reported as inhibition, at one concentration (the size of the read-out at that concentration, not a potency): 46.1%
The estimate for compound 3 lay 24.1 percentage points below the measured number, outside the stated range (above it).
By their numbers in this assay, from the lowest: compound 1; then compound 2; then compound 3.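

In this assay, methoxy in place of bromo on this aromatic carbon, meta to a fused ring and para to a fused ring, goes with a number 19.8 percentage points higher from compound 2 to compound 3 (beyond the scatter), so the read-out is sensitive to the substituent at this position. The earlier step concerned the group on the carbonyl carbon as a whole, whereas this exchange alters one substituent on the six-membered aromatic ring, replacing bromo with methoxy, which brings 1 hydrogen-bond acceptor where bromo has 0. No evidence at hand explains the rise in inhibition.

The compounds shown leave open whether the rise is specific to methoxy, since a hydroxy group, a longer ethoxy chain, an amine or a carboxylic acid on the same carbon could each give a different number, and neither bromo nor methoxy can yet be set against plain hydrogen there. They also leave open whether methoxy at this position would give a similar step with the methyl-bearing indolyl group of compound 1, and all of these readings are inhibition at one concentration, not potencies.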